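Swapping a methoxypyridine for a hydroxyphenyl on a chalcone

The source may report more compounds than this note shows. Statements on the series, on what has been measured and on what is new or still open speak of the compounds shown alone.

Measured so far:
compound 1, `CCN(CC)c1ccc(/C=C/C(=O)c2ccc(OC)c3c2OC(C)(C)C=C3)cc1`: 610 nM
compound 2, `COc1ccc(/C=C/C(=O)c2ccc(OC)c3c2OC(C)(C)C=C3)cn1`: > 10000 nM

Both compounds share the same core, a chromene ketone joined through a double-bonded two-carbon chain to an aromatic ring, and were tested in a functional assay on SK-OV-3 cells (Homo sapiens) for antiproliferative activity, read by MTT assay, with a stated time of 24 h; on this read-out higher numbers stand for weaker inhibition and lower numbers for stronger inhibition. Compound 1, which carries a diethylamino-substituted phenyl on that chain, gives 610 nM. Compound 2, which carries a 6-methoxypyridin-3-yl instead, returns only a limit, > 10000 nM, so no number is known for it; it sits at the limit of > 10000 nM in this assay, at which 1 of the 2 values shown sits, the weaker end of what this assay can report.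

Compound 3, `COc1ccc(C(=O)/C=C/c2cccc(O)c2)c2c1C=CC(C)(C)O2`, has not yet been measured. It differs from compound 2 in one place: 3-hydroxyphenyl in place of 6-methoxypyridin-3-yl on a double-bonded chain carbon bound to a double-bonded chain carbon. Because compound 2 sits at the limit of > 10000 nM in this assay, at which 1 of the 2 values shown sits, only a move toward stronger inhibition, or no move at all, can become visible. Going by the values given here, with a single comparison of this kind and no matched step to lean on, the expected step is a modest one, estimated at an at least 2.0-fold lower number from compound 2 to compound 3 (0.30 log units; that floor lies within the scatter). The estimate for compound 3 in this assay is 5000 nM, with a range from 1000 nM to 20000 nM.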

Compound 3, half-maximal inhibitory concentration: > 10000 nM
Compound 3: no number, only a limit; the forecaster's own chance of this, stated with the estimate: 35%; at least 2.0-fold (0.30 log units) between middle value and limit.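

Compound 2 and compound 3 both return only a limit, so the step from one to the other cannot be read: the limit of > 10000 nM in this assay, at which 2 of the 3 values shown sit.

Going by these compounds, what stays open is whether 3-hydroxyphenyl in place of 6-methoxypyridin-3-yl changes the result in this assay at all, and if it does, in which direction and by how much.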